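Methoxy for Trifluoromethyl on the Benzamide Ring

The source may hold more compounds than are shown below. What is called first, only, known or untested is meant among the compounds shown, and "the series" means these compounds.

Compound 1 `O=C(Nc1cccc(/C=C/C(=O)c2nc3ccccc3[nH]2)c1)c1ccccc1`: 8340 nM
Compound 2 `Cc1cccc(C(=O)Nc2cccc(/C=C/C(=O)c3nc4ccccc4[nH]3)c2)c1`: 4880 nM
Compound 3 `O=C(Nc1cccc(/C=C/C(=O)c2nc3ccccc3[nH]2)c1)c1cccc(C(F)(F)F)c1`: 9570 nM

In a functional assay on 143B cells (Homo sapiens) for antiproliferative activity, read by MTT assay, with a stated time of 48 h (on this read-out lower numbers stand for stronger inhibition and higher numbers for weaker inhibition), compound 3 gives the highest of these three numbers, though all three sit close together: the step of a 1.1-fold higher number from compound 1 to compound 3 (0.06 log units; within the scatter) and the step of a 2.0-fold higher number from compound 2 to compound 3 (0.29 log units; within the scatter) both stay within the scatter, as does the step of a 1.7-fold lower number from compound 1 to compound 2 (0.23 log units; within the scatter).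

Compound 4 `COc1cccc(C(=O)Nc2cccc(/C=C/C(=O)c3nc4ccccc4[nH]3)c2)c1` differs from compound 3 by one change: methoxy in place of trifluoromethyl on an aromatic carbon. Three swaps at this same carbon have been measured, and none of them moved the number beyond the scatter, so the expectation for this assay is a step of no clear size, neither up nor down.

For compound 4 the estimate is 7000 nM, with a range from 3000 nM to 18000 nM, an expected step of a 1.4-fold lower number from compound 3 to compound 4 (0.14 log units; within the scatter).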

Compound 4, half-maximal inhibitory concentration: 4610 nM
Beside the measured number, compound 4's estimate is 1.5-fold (0.18 log units) above it, and the stated range covers the measured number.
By their numbers in this assay, from the lowest: compounds 4, 2, 1 and 3 (each within the scatter of the next, the first and the last beyond it).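

Among these compounds, a step of a 2.1-fold lower number from compound 3 to compound 4 (0.32 log units; beyond the scatter) is the first swap at this carbon to pass the scatter, if only modestly, so in this assay the choice of group here can matter. Methoxy stands apart only from trifluoromethyl: a 1.1-fold lower number from compound 2 to compound 4 (0.02 log units; within the scatter) and a 1.8-fold lower number from compound 1 to compound 4 (0.26 log units; within the scatter) both stay within the scatter, leaving it level with methyl and hydrogen. Nothing available accounts for this gap. Going by these compounds, whether an amine, a carboxylic acid or a longer chain such as ethoxy on this carbon would shift the number further remains open.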